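A few compounds are considered here, and "the series" means these few. Any claim that something is new, unique, unknown or untested is made for them only; others in the source may bear on it.

Compound 1 `O=C1/C(=C/c2cccc(F)c2)CN(S(=O)(=O)c2ccc(F)cc2)C/C1=C\c1cccc(F)c1` gives 21900 nM in an ADME assay on L02 cells (Homo sapiens) for cytotoxicity, read by MTT assay, with a stated time of 24 h; a lower number here means a stronger inhibitor, a higher number a weaker inhibitor. Compound 2 `O=C1/C(=C/c2cccc(F)c2)CN(S(=O)(=O)c2ccc(Cl)cc2)C/C1=C\c1cccc(F)c1` differs from it by one change, (chloro in place of fluoro on an aromatic carbon), and in this assay compound 2 gives 15700 nM, so that the step is a 1.4-fold lower number from compound 1 to compound 2 (0.14 log units; within the scatter). Compound 3 `O=C1/C(=C/c2ccc(F)cc2)CN(S(=O)(=O)c2ccc(F)cc2)C/C1=C\c1ccc(F)cc1` shares its atoms with compound 1, joined differently; how the two cores differ is not broken down here. In this assay compound 3 gives 14800 nM. Compound 4 `O=C1/C(=C/c2ccc(F)cc2)CN(S(=O)(=O)c2ccc(Cl)cc2)C/C1=C\c1ccc(F)cc1` is not yet measured. It differs from compound 3 by chloro in place of fluoro on an aromatic carbon, the same change that separates compound 2 from compound 1, at the same kind of place. The step from compound 3 to compound 4 in this assay is expected to be a 1.3-fold lower number from compound 3 to compound 4 (0.13 log units; within the scatter), resting on the step from compound 1 to compound 2 of a 1.4-fold lower number from compound 1 to compound 2 (0.14 log units; within the scatter). Compound 4 is therefore estimated at 11000 nM, expected to lie between 5000 nM and 25000 nM.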

Compound 4, half-maximal inhibitory concentration: 15500 nM
Compound 4: the middle estimate sits 1.4-fold (0.15 log units) below what was measured; low and high end bracket the measured number.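

In this assay, going from (4-fluorophenyl)sulfonyl to (4-chlorophenyl)sulfonyl on the core of compound 3 gives a 1.0-fold higher number from compound 3 to compound 4 (0.02 log units; within the scatter). Set beside the earlier step, the change reads alike on both cores: the same change on two cores in this assay, a 1.4-fold lower number (0.14 log units; within the scatter) from compound 1 to compound 2 and a 1.0-fold higher number (0.02 log units; within the scatter) from compound 3 to compound 4, 1.5-fold (0.16 log units) apart, within the scatter of two such steps

Among the compounds shown here, this shows only that the change moved the number beyond the scatter on neither core, so there is no measurable effect to carry across, and it says nothing about cores other than these two. The compounds shown leave open whether a different group in the same place, such as a methoxy group, a nitrile or an amine, would give a step beyond the scatter. They also leave open what a carboxylic acid or a longer chain there would do.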